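Replacing chloro with vinyl in compound 1

A few compounds are considered here, and "the series" means these few. Any claim that something is new, unique, unknown or untested is made for them only; others in the source may bear on it.

In a functional assay on the whole organism with Mus musculus as the target (a lower number here means that less compound is needed, a higher number that more compound is needed for the effect), compound 1 (`CN(c1ccncc1)n1cccc1Cl`) gives > 20 mg/kg as a limit of the assay, not a number. Compound 2 (`CCCN(c1ccncc1)n1cccc1Cl`) also gives only a limit, > 20 mg/kg in this case. Compound 3 (`C=Cc1cccn1N(C)c1ccncc1`) keeps the core of compound 1 and differs by vinyl in place of chloro on an aromatic carbon in a single swap: vinyl in place of chloro on an aromatic carbon. For the measured compounds named here, the only measured step is a step that the two limits leave unreadable from compound 1 to compound 2 and it concerns a different change, so it offers no size to carry over. The evidence available is the limit of > 20 mg/kg in this assay, at which 2 of the 2 values shown sit, and it sets no direction for the swap. In this assay the expectation is therefore no step beyond the usual scatter, and a step that the limit leaves unreadable from compound 1 to compound 3 is an estimate with little support. For compound 3 the expected value is 30 mg/kg within an estimated range of 10 mg/kg to 80 mg/kg and a limit may again be the outcome.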

Compound 3, dose for half-maximal effect: 8.3 mg/kg
Compound 3: the middle estimate sits 3.6-fold (0.56 log units) above what was measured, and the stated range ends above it.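

Vinyl in place of chloro on this aromatic carbon, next to the ring nitrogen, gives in this assay an at least 2.4-fold lower number from compound 1 to compound 3 (0.38 log units; beyond the scatter). Compound 3 is thus the first compound shown with a real number, and the change behind it brings 2 heavy atoms and a double bond outside aromatic rings in place of 1 chlorine, with no hydrogen-bond donors or acceptors on either side. Compound 1 and compound 2 both stay at a limit of the assay, and the step between them cannot be read: the limit of > 20 mg/kg in this assay, at which 2 of the 3 values shown sit.

As far as these compounds go, whether an ethyl or an ethynyl group on the same aromatic carbon would match vinyl stays open, so the double bond is not separated from the added carbon. From the compounds shown here alone, the full size of the step also stays open, as does whether vinyl has the same effect with the longer chain of compound 2.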